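Compound 2 to compound 3: losing one chloro

The compounds below may be only part of what the source reports. "The series", "measured", "known", "first", "only" and "open" are said of these compounds alone.

In a physicochemical assay for lipophilicity, measured as octanol-water partition (on this read-out lower numbers stand for lower lipophilicity and higher numbers for higher lipophilicity), compound 1 `COc1ccccc1C(=O)O[C@@H]1C[C@H](C)CC[C@H]1C(C)C` reads 4.57 and compound 2 `CC(C)[C@@H]1CC[C@@H](C)C[C@H]1OC(=O)c1ccc(Cl)cc1Cl` reads 5.86, the higher of the two numbers, with the gap beyond the scatter. Compound 3 `CC(C)[C@@H]1CC[C@@H](C)C[C@H]1OC(=O)c1ccccc1Cl` is not yet measured and differs from compound 2 by hydrogen in place of chloro on an aromatic carbon. Going by the values given here, no measured pair shows this change, so its size rests on judgement alone. A fall beyond the scatter in this assay is expected, with a number 0.66 log units lower from compound 2 to compound 3 (beyond the scatter) as the estimated step. Compound 3 is estimated at 5.2 (4.85 to 5.55).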

Compound 3, partition coefficient: 5.34
Estimate against measurement, compound 3: 0.14 log units below; low and high end bracket the measured number.
By their numbers in this assay, from the lowest: compound 1; then compound 3; then compound 2.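

The step of a number 0.52 log units lower from compound 2 to compound 3 (beyond the scatter) gives a first measured size in this assay for hydrogen in place of chloro on an aromatic carbon, at the place para to a large group and meta to a chloro group. The step of a number 0.77 log units higher from compound 1 to compound 3 (beyond the scatter) gives chloro in place of methoxy on an aromatic carbon, which makes compound 3 the single-change link between compound 1 and compound 2.

From the compounds shown here alone, how an amine or a carboxylic acid on that aromatic carbon would read remains open. Nothing at hand speaks to the cause of either step.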